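The source may hold more compounds than are shown below. What is called first, only, known or untested is meant among the compounds shown, and "the series" means these compounds.

The study concerns inhibitors of a chaperone pair, assessed in an assay on cells for inhibition of HSP60/HSP10 (Homo sapiens), with a stated time of 60 min; a lower number here means a stronger inhibitor, a higher number a weaker inhibitor. Compound 1 `Cc1ccccc1S(=O)(=O)Nc1ccc2oc(-c3ccccc3)nc2c1` gives in this assay only a limit, > 100000 nM, and no number. Compound 3 `COc1ccccc1S(=O)(=O)Nc1ccc(-c2nc3ccccc3o2)cc1` likewise returns only the limit of > 100000 nM in this assay. Going by the values given here, compound 2 `O=S(=O)(Nc1ccc(-c2nc3ccccc3o2)cc1)c1ccc(C(F)(F)F)cc1` is the one member of the set with a measured value, 50000 nM in this assay. Compound 1 thus stands at the weak end of what this assay can report, a position it shares with compound 3, both sitting at the limit of > 100000 nM in this assay, at which 2 of the 3 values shown sit.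

Compound 4 `O=S(=O)(Nc1ccc2oc(-c3ccccc3)nc2c1)c1cccc(F)c1` has not yet been measured. It differs from compound 1 in one place: 3-fluorophenyl in place of 2-methylphenyl on a sulfonyl sulfur. Among the compounds with values here, no pair of measured compounds carries that change, so its size and direction are not yet known. Since compound 1 gives only a limit in this assay, compound 4 is expected to land near that same limit, with the step of a number no higher from compound 1 to compound 4 (the limit leaves the size open) expected to be no larger than the usual scatter. Compound 4 is accordingly estimated at 100000 nM, between 30000 nM and 300000 nM in this assay.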

Compound 4, half-maximal inhibitory concentration: > 100000 nM
Compound 4 was reported as a limit; the forecaster's own chance of this, stated with the estimate: 70%; the middle value sits exactly at the limit.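

In this assay compound 4 gives > 100000 nM, which is a limit and not a number. Going by these compounds alone, compound 1 also gives only a limit, so no step between compound 1 and compound 4 can be read. The compounds shown leave open how 3-fluorophenyl and 2-methylphenyl on a sulfonyl sulfur compare in this assay.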